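A few compounds are considered here, and "the series" means these few. Any claim that something is new, unique, unknown or untested is made for them only; others in the source may bear on it.

Measured compounds:
compound 1 `COc1cc(OC)c(C(=O)/C=C/c2cn(-c3ccccc3)nc2-c2ccsc2)c(OC)c1` gives 6100 nM in a functional assay on Huh-7 cells (Homo sapiens) for inhibition, read by sulforhodamine B assay, with a stated time of 72 h; a higher number here means a weaker inhibitor, a lower number a stronger inhibitor
compound 2 `COc1ccc(C(=O)/C=C/c2cn(-c3ccccc3)nc2-c2ccsc2)c(OC)c1` gives 3000 nM in this assay

Among the compounds with values here, compound 1 has the highest number of the two measured in this assay; its nearest neighbour is compound 2, and a 2.0-fold lower number from compound 1 to compound 2 (0.31 log units; beyond the scatter) is the only step in this set. Compound 3 `COc1cc(OC)c(C(=O)/C=C/c2cn(-c3ccccc3)nc2-c2cccnc2)c(OC)c1` differs from compound 1 at one place: pyridin-3-yl in place of thiophen-3-yl on an aromatic carbon. Within the data shown here, the one measured step concerns a methoxy group on the other end of the shared core and does not touch the five-membered ring where the change to compound 3 sits, so nothing measured here speaks to that change directly. Among the measured compounds shown here, with no step bearing on it, the expectation for compound 3 in this assay is a number near that of compound 1, with no step beyond the scatter, and the estimated step is a 1.0-fold lower number from compound 1 to compound 3 (0.01 log units; within the scatter). Compound 3 is therefore estimated at 6000 nM, within a range from 2000 nM to 18000 nM.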

Compound 3, half-maximal inhibitory concentration: 500 nM
Beside the measured number, compound 3's estimate is 12-fold (1.08 log units) above it; measured number outside the range, below it.
By their numbers in this assay, from the lowest: compound 3; then compound 2; then compound 1.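

Replacing thiophen-3-yl with pyridin-3-yl gives a 12-fold lower number from compound 1 to compound 3 (1.09 log units; beyond the scatter) in this assay. Within the data shown here, this shows that the aromatic group at this position, on an aromatic carbon next to the ring nitrogen, can shift the number much further than the only earlier step, a 2.0-fold lower number from compound 1 to compound 2 (0.31 log units; beyond the scatter), which was a modest change at a methoxy group elsewhere on the shared core. Nothing available accounts for the stronger inhibition seen with pyridin-3-yl.

The change alters both the ring size and the hetero atom, so the compounds shown leave open whether a plain phenyl, a pyridin-4-yl or a furan-3-yl group would give a similar number. They also leave open whether removing that methoxy group would have the same effect with pyridin-3-yl in place.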